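A few compounds are considered here, and "the series" means these few. Any claim that something is new, unique, unknown or untested is made for them only; others in the source may bear on it.

Measured compounds:
compound 1, `COc1ccc(-c2cc(/C=C/C(=O)c3ccc(N)cc3)[nH]n2)cc1`: -16%
compound 2, `COc1cc(-c2cc(/C=C/C(=O)c3ccc(N)cc3)[nH]n2)cc(OC)c1OC`: -45%
compound 3, `COc1cc(-c2cc(/C=C/C(=O)c3ccc(F)c(F)c3)[nH]n2)cc(OC)c1OC`: 15%

All three were tested in a functional assay on SN12C cells (Homo sapiens) for cytotoxicity, read by sulforhodamine B assay, with a stated time of 48 h, tested at 10 uM; a lower number here means a stronger effect, a higher number a weaker effect of the compound at the concentration tested. Compound 2 gives the lowest number of the three; compound 1 comes nearest to it, and compound 3 lies furthest away. Among the measured compounds shown here, the one measured step between compounds that differ in a single place, a number 60 percentage points higher from compound 2 to compound 3 (beyond the scatter), concerns the group on the carbonyl carbon and not the aromatic ring that carries the methoxy groups.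

The unmeasured compound 4, `COc1ccc(-c2cc(/C=C/C(=O)c3ccc(N)cc3)[nH]n2)cc1OC`, differs from compound 2 by hydrogen in place of methoxy on an aromatic carbon. For the measured compounds named here, no measured step alters the number of methoxy groups on that ring by itself, so the step to compound 4 has no direct counterpart. Compound 1 carries a single methoxy group on that ring and gives -16%, whereas compound 2 carries three and gives -45%. Compound 4, with two methoxy groups, sits between them in structure, and its number is expected to sit between them as well. Compound 4 is therefore expected to give -30% in this assay, with a range from -50% to -5%. The expected step is a number 15 percentage points higher from compound 2 to compound 4 (beyond the scatter), a modest rise in the number that cannot be pinned down closely on the data at hand.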

Compound 4, a percentage reported as activity, at one concentration (the size of the read-out at that concentration, not a potency): 14%
For compound 4 the middle estimate is 44 percentage points below the measured one; measured number outside the range, above it.
By their numbers in this assay, from the lowest: compound 2; then compound 1; then compounds 4 and 3 (each within the scatter of the next).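

In this assay, the methoxy group at this place, ortho to a methoxy group and meta to a methoxy group, carries a large part of what sets compound 2 apart: replacing it with hydrogen gives a number 59 percentage points higher from compound 2 to compound 4 (beyond the scatter). The other step to compound 4 runs the opposite way in terms of methoxy count, since methoxy in place of hydrogen on an aromatic carbon gives a number 30 percentage points higher from compound 1 to compound 4 (beyond the scatter), so adding a methoxy group raises the number in one step and lowers it in the other, and the number of methoxy groups on this ring does not by itself order compounds 1, 4 and 2. Nothing available here accounts for either step.

Going by these compounds, it remains open whether another group at this place, such as a hydroxyl, an ethoxy or a fluorine, would hold the number near that of compound 2 or move it towards that of compound 4. On these data alone, it is equally open whether removing this methoxy group would have a similar effect with the 3,4-difluorophenyl group of compound 3 on the carbonyl carbon in place of the 4-aminophenyl group.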